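The compounds below may be only part of what the source reports. "The series", "measured", "known", "first", "only" and "open" are said of these compounds alone.

Measured so far in a functional assay on HepG2 cells (Homo sapiens) for cytotoxicity, read by MTT assay, with a stated time of 48 h; a lower number here means a stronger inhibitor, a higher number a weaker inhibitor:
- compound 1 `COc1cc(/C=C/C(=O)/C=C/c2nc3cc(C)ccc3n2C)ccc1O`: 4200 nM
- compound 2 `COc1ccc2c(c1)nc(/C=C/C(=O)/C=C/c1ccc(O)c(OC)c1)n2C`: 3800 nM
- compound 3 `COc1cc(/C=C/C(=O)/C=C/c2nc3cc(Cl)ccc3n2C)ccc1O`: 4000 nM

Compound 3, at 4000 nM, cannot be separated from the other two compounds. The steps are a 1.1-fold lower number from compound 1 to compound 3 (0.02 log units; within the scatter) and a 1.1-fold higher number from compound 2 to compound 3 (0.02 log units; within the scatter), and the remaining pair gives a 1.1-fold lower number from compound 1 to compound 2 (0.04 log units; within the scatter).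

Next is compound 4 `COc1cc(/C=C/C(=O)/C=C/c2nc3cc([N+](=O)[O-])ccc3n2C)ccc1O`, with nitro in place of chloro on an aromatic carbon. All three measured steps exchange the group at this same place, so they are the ones that bear on the change. Methyl, methoxy and chloro give no measurable separation here, and none of the three compounds goes against that. None of these steps involves nitro, however, so the evidence is indirect and the range is kept wide.

In this assay, no step beyond the scatter is expected, and the estimate is a 1.1-fold lower number from compound 3 to compound 4 (0.02 log units; within the scatter). For compound 4 the estimated value is 3800 nM, with an expected range of 1800 nM to 8000 nM.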

Compound 4, half-maximal inhibitory concentration: 3700 nM
For compound 4 the middle estimate is 1.0-fold (0.01 log units) above the measured one; low and high end bracket the measured number.
By their numbers in this assay, from the lowest: compounds 4, 2, 3 and 1 (each within the scatter of the next).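

In this assay, nitro joins methyl, methoxy and chloro at this aromatic carbon with no separation from any of them: chloro (a 1.1-fold lower number from compound 3 to compound 4 (0.03 log units; within the scatter)), methoxy (a 1.0-fold lower number from compound 2 to compound 4 (0.01 log units; within the scatter)) and methyl (a 1.1-fold lower number from compound 1 to compound 4 (0.06 log units; within the scatter)). Nitro brings three heavy atoms and two hydrogen-bond acceptors where chloro has one heavy atom and none, so the lack of separation now spans a wider difference in these counts than the earlier compounds covered. No measurement at hand explains this lack of separation.

From the compounds shown here alone, whether it extends to an amine or a carboxylic acid at this aromatic carbon remains open. Every step shown exchanges the group at this one place, so whether a change elsewhere on the shared core moves the number is also open.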